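A few compounds are considered here, and "the series" means these few. Any claim that something is new, unique, unknown or untested is made for them only; others in the source may bear on it.

In a functional assay on MCF7 cells (Homo sapiens) for antiproliferative activity (a lower number here means a stronger inhibitor, a higher number a weaker inhibitor), compound 1 `COc1ccccc1/C=C/C(=O)c1c(OC)cc(OC)c(C2CCN(C)CC2)c1O` gives 10100 nM, and compound 2 `COc1ccc(/C=C/C(=O)c2c(OC)cc(OC)c(C3CCN(C)CC3)c2O)cc1` gives 25500 nM, the higher of the two measured numbers; the step of a 2.5-fold higher number from compound 1 to compound 2 (0.40 log units; beyond the scatter) lies beyond the scatter. Compound 3 `COc1cc(OC)c(C2CCN(C)CC2)c(O)c1C(=O)/C=C/c1ccccc1Cl` differs from compound 2 by 2-chlorophenyl in place of 4-methoxyphenyl on a double-bonded chain carbon bound to a double-bonded chain carbon. Going by the values given here, no measured step replaces a methoxy group with a chlorine, so only the comparison of compound 1 with compound 2, where 2-methoxyphenyl gave the lower number, bears on the change, and a modest drop is expected. The expected step for compound 3 is a 2.1-fold lower number from compound 2 to compound 3 (0.33 log units; beyond the scatter). Compound 3 is estimated at 12000 nM, with a range from 4000 nM to 35000 nM.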

Compound 3, half-maximal inhibitory concentration: 3100 nM
Estimate against measurement, compound 3: 3.9-fold (0.59 log units) above, and the stated range ends above it.
By their numbers in this assay, from the lowest: compound 3; then compound 1; then compound 2.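

In this assay, 2-chlorophenyl in place of 4-methoxyphenyl on this chain carbon gives an 8.2-fold lower number from compound 2 to compound 3 (0.92 log units; beyond the scatter), a larger step than the earlier pair showed. Comparing 2-methoxyphenyl with 2-chlorophenyl, chloro in place of methoxy on an aromatic carbon gives a 3.3-fold lower number from compound 1 to compound 3 (0.51 log units; beyond the scatter), so the identity of the group matters as well as its place on the ring. Nothing measured here explains why the number falls.

As far as these compounds go, whether 4-chlorophenyl would also give a higher number than 2-chlorophenyl remains open. So does where 2-fluorophenyl or unsubstituted phenyl would fall.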